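From 3-chlorophenyl to 4-chlorophenyl on the shared core

A few compounds are considered here, and "the series" means these few. Any claim that something is new, unique, unknown or untested is made for them only; others in the source may bear on it.

In a functional assay on A549 cells (Homo sapiens) for antiproliferative activity, read by MTT assay, with a stated time of 48 h (on this read-out higher numbers stand for weaker inhibition and lower numbers for stronger inhibition), compound 1 `COc1ccc(-c2nc3cccc(-c4cc(OC)c(OC)c(OC)c4)c3o2)cc1F` gives 1800 nM, and compound 2 `COc1cc(-c2cccc3nc(-c4ccc(F)cc4)oc23)cc(OC)c1OC` gives 8700 nM. Compound 3 `COc1cc(-c2cccc3nc(-c4cccc(Cl)c4)oc23)cc(OC)c1OC` is the weakest of the three, and its > 25000 nM is a limit of the assay and not a number.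

The unmeasured compound 4 `COc1cc(-c2cccc3nc(-c4ccc(Cl)cc4)oc23)cc(OC)c1OC` has 4-chlorophenyl in place of 3-chlorophenyl on an aromatic carbon. The nearest measured step is an at least 2.8-fold higher number from compound 2 to compound 3 (0.45 log units; beyond the scatter), with 3-chlorophenyl in place of 4-fluorophenyl. Two more distant steps, a 4.8-fold higher number from compound 1 to compound 2 (0.68 log units; beyond the scatter) and an at least 13-fold higher number from compound 1 to compound 3 (1.14 log units; beyond the scatter), both start from 3-fluoro-4-methoxyphenyl and show that this group matters to the read-out of this assay.

The 4-chlorophenyl group of compound 4 most resembles the 4-fluorophenyl group of compound 2, which gives 8700 nM, so a modest move towards stronger inhibition is expected. The expected change is an at least 2.2-fold lower number from compound 3 to compound 4 (0.35 log units; beyond the scatter). For compound 4 the estimated value is 11000 nM, with an expected range from 4000 nM to 25000 nM.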

Compound 4, half-maximal inhibitory concentration: 5600 nM
Estimate against measurement, compound 4: 2.0-fold (0.29 log units) above; measured number inside the range.
By their numbers in this assay, from the lowest: compound 1; then compounds 4 and 2 (each within the scatter of the next). At a limit, above all of these: compound 3.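

With the same atoms joined differently, 4-chlorophenyl in place of 3-chlorophenyl gives an at least 4.4-fold lower number from compound 3 to compound 4 (0.64 log units; beyond the scatter) in this assay, so the place of the chlorine on the phenyl ring alone moves the read-out, though compound 3 stands at a limit of the assay, which leaves that step only bounded: the limit of > 25000 nM in this assay, at which 1 of the 4 values shown sits. Chloro in place of fluoro on the phenyl ring does not separate the two compounds: a 1.6-fold lower number from compound 2 to compound 4 (0.19 log units; within the scatter). The 3-fluoro-4-methoxyphenyl group still gives stronger inhibition than 4-chlorophenyl: a 3.1-fold higher number from compound 1 to compound 4 (0.49 log units; beyond the scatter).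

Going by these compounds, whether 4-methoxyphenyl without the fluoro would keep the stronger inhibition of compound 1 stays open, as does the effect of an amine or a carboxylic acid on this phenyl ring. On these data alone, it is also open whether 3-fluorophenyl would lose inhibition as 3-chlorophenyl does.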